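From 4-fluorophenyl to 3-(trifluoromethyl)phenyl on a shared core

The source may hold more compounds than are shown below. What is called first, only, known or untested is meant among the compounds shown, and "the series" means these compounds.

Measured so far in an ADME assay on cells (Epithelial cell, Homo sapiens) for antiproliferative activity, read by MTT assay, with a stated time of 48 h (on this read-out lower numbers stand for stronger inhibition and higher numbers for weaker inhibition), with these results

Compound 1 `COC(=O)/C(=C/c1ccccc1)CN1C(=O)[C@@H](OC)[C@H]1c1ccc(F)cc1` gives 27900 nM
Compound 2 `CCOC(=O)/C(=C/c1ccccc1)CN1C(=O)[C@@H](OC)[C@H]1c1cccc([N+](=O)[O-])c1` gives "not toxic" (no number reported)
Compound 3 `COc1ccc(OC)c([C@@H]2[C@H](OC)C(=O)N2C/C(C#N)=C/c2ccccc2)c1` gives > 100000 nM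

Among the compounds with values here, compound 1 is the only compound here with a true number, 27900 nM as its half-maximal inhibitory concentration. Compound 2 was reported as "not toxic" (no number reported) with no number attached. Compound 3 gives > 100000 nM as a limit of the assay and not as a number.

Compound 4 `COC(=O)/C(=C/c1ccccc1)CN1C(=O)[C@@H](OC)[C@H]1c1cccc(C(F)(F)F)c1` has not yet been measured. Within the data shown here, it keeps the core of compound 1 and carries 3-(trifluoromethyl)phenyl in place of 4-fluorophenyl on a saturated ring carbon as its only change.

Among the measured compounds shown here, no two measured compounds differ in just one place, so the data give no direct guide to the size of this swap. In this assay no step beyond the usual scatter is expected, with at most a slight weakening. The estimated change is a 1.3-fold higher number from compound 1 to compound 4 (0.10 log units; within the scatter) and is expected to stay within that scatter. This expectation rests on compound 1 with 27900 nM as the sole numerical anchor. Neither of the other measured compounds gave a number, so the range is left wide on the weaker side. For compound 4 the estimate is 35000 nM with 10000 nM and 100000 nM as the expected ends of the range.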

Compound 4, half-maximal inhibitory concentration: 71800 nM
Beside the measured number, compound 4's estimate is 2.1-fold (0.31 log units) below it; the range from low to high includes it.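

In this assay, the swap of 4-fluorophenyl for 3-(trifluoromethyl)phenyl on a saturated ring carbon of the four-membered non-aromatic ring gives a 2.6-fold higher number from compound 1 to compound 4 (0.41 log units; beyond the scatter), a modest step but one that lies outside the usual scatter. Within the data shown here, none of the earlier compounds differed in just one place, so this is the first sign that the aryl group at this position affects the read-out, with the shared core unchanged and the number moving towards weaker inhibition. Compound 3 gives a limit and not a number, and that limit marks the weak end of what this assay reports here: the limit of > 100000 nM in this assay, at which 1 of the 4 values shown sits.

The compounds shown leave open whether the change comes from the kind of group on the phenyl ring or from where it sits, as this swap alters both; 3-fluorophenyl or 4-(trifluoromethyl)phenyl on the shared core would separate the two. From the compounds shown here alone, compound 1 gives 27900 nM, and it also stays open whether an unsubstituted phenyl or a 4-aminophenyl at this ring carbon would give stronger inhibition.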